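The source may hold more compounds than are shown below. What is called first, only, known or untested is meant among the compounds shown, and "the series" means these compounds.

Within the data shown here, compound 1 `COC1=C(C)C(=O)/C(=C(O)/C=C/c2ccc(Br)cc2)C(=O)C1(C)C` gives 3.6 ug/mL in a functional assay on HUVEC cells (Homo sapiens) for cytotoxicity (on this read-out higher numbers stand for an effect only at larger amounts of compound and lower numbers for an effect already at smaller amounts), and stands highest of the two numbers measured so far; its nearest neighbour is compound 2 `COC1=C(C)C(=O)/C(=C(O)/C=C/c2cc(C)cc(C)c2)C(=O)C1(C)C` with 2.5 ug/mL in this assay, and the step of a 1.4-fold lower number from compound 1 to compound 2 (0.16 log units; within the scatter) lies within the scatter. Compound 3 `COC1=C(C)C(=O)/C(=C(O)/C=C/c2nccs2)C(=O)C1(C)C` differs from compound 1 by 1,3-thiazol-2-yl in place of 4-bromophenyl on a double-bonded chain carbon bound to a double-bonded chain carbon. Among the measured compounds shown here, the only measured step that bears on such a change, one ring for another on a double-bonded chain carbon bound to a double-bonded chain carbon, is a 1.4-fold lower number from compound 1 to compound 2 (0.16 log units; within the scatter), within the scatter, so no step beyond the scatter is expected for compound 3 in this assay, meaning a 1.0-fold lower number from compound 1 to compound 3 (0.01 log units; within the scatter). For compound 3 the expected value in this assay is 3.5 ug/mL, in the range 1.5 ug/mL to 8 ug/mL.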

Compound 3, concentration for half-maximal effect: 1.6 ug/mL
For compound 3 the middle estimate is 2.2-fold (0.34 log units) above the measured one; measured number inside the range.
By their numbers in this assay, from the lowest: compounds 3, 2 and 1 (each within the scatter of the next, the first and the last beyond it).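

In this assay, a ring change on a double-bonded chain carbon bound to a double-bonded chain carbon now moves the number beyond the scatter: 1,3-thiazol-2-yl in place of 4-bromophenyl gives a 2.3-fold lower number from compound 1 to compound 3 (0.35 log units; beyond the scatter). The same ring in place of 3,5-dimethylphenyl stays within the scatter, at a 1.6-fold lower number from compound 2 to compound 3 (0.19 log units; within the scatter), so the place responds to some ring changes but only modestly so far. No measurement here accounts for the step.

Open, as far as these compounds go, is whether the ring size, the hetero atoms or the loss of bromine carries the step. Also open, from the compounds shown here alone, is how an unsubstituted phenyl, a pyridyl or a ring bearing an amine or a carboxylic acid would read at this place.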